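Undefined stereocentre in the phosphorylated lipid amide series

The source may hold more compounds than are shown below. What is called first, only, known or untested is meant among the compounds shown, and "the series" means these compounds.

Values in a functional assay on cells (Macrophage, Mus musculus) for activation; a higher number here means that more compound is needed for the effect, a lower number that less compound is needed:
compound 1 `CCCCCCCCCCCC(=O)O[C@H](CCCCCCCCCCC)CC(=O)N[C@H](CCOP(=O)(O)O)C(=O)NCCC[C@H](CO)NC(=O)C[C@H](O)CCCCCCCCCCC`: 1.85 ug/mL
compound 2 `CCCCCCCCCCCC(=O)O[C@H](CCCCCCCCCCC)CC(=O)N[C@@H](CCOP(=O)(O)O)C(=O)NCCC[C@H](COP(=O)(O)O)NC(=O)C[C@H](O)CCCCCCCCCCC`: 0.15 ug/mL
compound 3 `CCCCCCCCCCCC(=O)O[C@H](CCCCCCCCCCC)CC(=O)N[C@@H](CCOP(=O)(O)O)C(=O)NCCC[C@H](CO)NC(=O)C[C@H](O)CCCCCCCCCCC`: 6.86 ug/mL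

Compound 3 has the highest number of the three in this assay, so it needs the most compound for activation, and its steps to both others are beyond the scatter. The next entry is compound 4 `CCCCCCCCCCCC(=O)O[C@H](CCCCCCCCCCC)CC(=O)NC(CCOP(=O)(O)O)C(=O)NCCC[C@H](CO)NC(=O)C[C@H](O)CCCCCCCCCCC`, not yet measured. The change is the two compounds have the same atoms and bonds; at least one stereo element is drawn with a configuration in one of them and without one in the other: 1 of 4 stereo elements differ; a stereocentre at a saturated chain carbon is drawn S in compound 3 and without a configuration in compound 4. Nothing is added or removed, and the structure does not show which configuration or mix of configurations the sample holds.

The step that bears on this is a 3.7-fold higher number from compound 1 to compound 3 (0.57 log units; beyond the scatter), which is modest. It can be assigned to configuration because of the fact that compounds 1 and 3 differ only in the configuration as drawn. The much larger a 46-fold higher number from compound 2 to compound 3 (1.66 log units; beyond the scatter) concerns a different change and gives no size for this one. If both configurations are present, the number for compound 4 should fall in the span set by compound 1 at 1.85 ug/mL and compound 3 at 6.86 ug/mL. A move toward lower numbers is therefore expected, smaller than the step between those two configurations and possibly not beyond the scatter. The expected step is a 2.1-fold lower number from compound 3 to compound 4 (0.32 log units; beyond the scatter). For compound 4 the estimated value is 3.3 ug/mL, with an expected range of 1.6 ug/mL to 7 ug/mL.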

Compound 4, half-maximal effective concentration: 3.53 ug/mL
Beside the measured number, compound 4's estimate is 1.1-fold (0.03 log units) below it; measured number inside the range.
By their numbers in this assay, from the lowest: compound 2; then compounds 1, 4 and 3 (each within the scatter of the next, the first and the last beyond it).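

In this assay compound 4, drawn without a configuration at this saturated chain carbon, cannot be separated from compound 3, with a 1.9-fold lower number from compound 3 to compound 4 (0.29 log units; within the scatter), and this step concerns that stereocentre alone: the fact that one of compounds 3 and 4 is drawn with a defined configuration and the other without, at the place where they differ. Compound 4 cannot be separated from compound 1 either, with a 1.9-fold higher number from compound 1 to compound 4 (0.28 log units; within the scatter), and this step likewise concerns only that stereocentre: the fact that one of compounds 1 and 4 is drawn with a defined configuration and the other without, at the place where they differ. The earlier compounds shown here gave only the gap between the two drawn configurations, a 3.7-fold higher number from compound 1 to compound 3 (0.57 log units; beyond the scatter); compound 4 adds that an undefined drawing at this carbon lies within the scatter of both, even though those two lie beyond the scatter of each other, so its number does not point to either configuration.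

Which configuration or mix of configurations the sample of compound 4 holds stays open, as the structure does not show it and the number cannot settle it. Also open, from the compounds shown here alone, is whether the gap between the two configurations would persist with a carboxylic acid in place of the phosphate group, or with the second phosphate group that compound 2 carries.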